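A few compounds are considered here, and "the series" means these few. Any claim that something is new, unique, unknown or untested is made for them only; others in the source may bear on it.

Measured so far:
- Compound 1, `O[C@@H]1Cc2ccccc2[C@H]1NC1CCN(CCCc2c[nH]c3ccc(-n4cnnc4)cc23)CC1`: 6.6 nM
- Compound 2, `c1cc(CNC2CCN(CCCc3c[nH]c4ccc(-n5cnnc5)cc34)CC2)co1`: 4.5 nM

These two compounds share one core and differ only in the group on the amine nitrogen. In an assay on CHO cells for displacement of a labelled ligand from 5-hydroxytryptamine receptor 1D (Homo sapiens) (on this read-out lower numbers stand for stronger inhibition and higher numbers for weaker inhibition), compound 2 gives the lowest of the two numbers, and its nearest neighbour is compound 1, which gives 6.6 nM. For the measured compounds named here, the only measured step is a 1.5-fold lower number from compound 1 to compound 2 (0.17 log units; within the scatter), so swapping the larger bicyclic group for the small furan ring on that nitrogen left the result essentially unchanged.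

Compound 3, `CC(=O)Nc1ccc(CNC2CCN(CCCc3c[nH]c4ccc(-n5cnnc5)cc34)CC2)cc1`, has not been measured. Compared with compound 2 the change is 4-acetamidophenyl in place of furan-3-yl on a saturated chain carbon bound to an amine nitrogen. The group on that carbon is now the largest of the three, and it carries an amide with a hydrogen-bond donor that the other two lack. Going by the values given here, the one step that bears on this, from compound 1 to compound 2, stayed within the scatter despite a sizeable change of shape at the same place. On that basis compound 3 is expected to sit close to compound 2, with a 1.2-fold higher number from compound 2 to compound 3 (0.09 log units; within the scatter) expected as the step. The estimate for compound 3 in this assay is 5.5 nM, with a likely range from 1.8 nM to 17 nM.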

Compound 3, half-maximal inhibitory concentration: 3 nM
Estimate against measurement, compound 3: 1.8-fold (0.26 log units) above; the range from low to high includes it.
By their numbers in this assay, from the lowest: compounds 3, 2 and 1 (each within the scatter of the next, the first and the last beyond it).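

In this assay the move to the largest group so far gives a 1.5-fold lower number from compound 2 to compound 3 (0.18 log units; within the scatter), so on a saturated chain carbon bound to an amine nitrogen, 4-acetamidophenyl, with 10 heavy atoms and 1 hydrogen-bond donor, can stand in place of furan-3-yl, with 5 heavy atoms and 0 donors, without a change that can be told from the scatter. For the compounds shown here, the other new comparison gives a 2.2-fold lower number from compound 1 to compound 3 (0.34 log units; beyond the scatter), the first step in this set to pass beyond the scatter, which shows that the group on this amine nitrogen can shift the number, although only modestly so far, and compound 2 stays within the scatter of both of the others. Nothing measured here explains either step.

A single compound cannot separate the part played by the amide hydrogen from that of the added size, and a 4-methoxybenzyl group, which has no such hydrogen, would be one way to pull the two apart. From the compounds shown here alone, it also remains open whether this position would tolerate a group with a carboxylic acid or an amine in place of the acetamido group.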